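Phenyl for methyl on the salicylanilide series

This account rests on a few compounds, and the source may have more. Where it says the series, first, only, none or still open, it means among the compounds named here.

The two measured compounds share the shared core and differ in their substituents. Compound 1 `O=C(Nc1cc(C(F)(F)F)cc(C(F)(F)F)c1)c1cc(Br)ccc1O` carries bromo and bis-trifluoromethyl groups and in a functional assay on KG-1 cells (Homo sapiens) for cytotoxicity, read by luminescence and CellTiter-Glo, with a stated time of 3 days (a lower number here means a stronger inhibitor, a higher number a weaker inhibitor), compound 1 gives 300 nM. Compound 2 `Cc1ccc(C(=O)Nc2ccc(C#N)cc2)c(O)c1` carries a methyl group and a nitrile and in this assay compound 2 gives 2560 nM; this is the highest of the two numbers, with compound 1 as its nearest neighbour, whose number is lower by a gap beyond the usual scatter.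

Compound 3 `N#Cc1ccc(NC(=O)c2ccc(-c3ccccc3)cc2O)cc1` is the next compound in the series and has not yet been measured. Its difference from compound 2 is phenyl in place of methyl on an aromatic carbon. For the measured compounds named here, no step of this kind has been measured between two compounds, so the expectation rests only on the spread between compound 2 and compound 1. Compound 3 is expected to give a lower number than compound 2, with a step of a 2.8-fold lower number from compound 2 to compound 3 (0.45 log units; beyond the scatter) that may exceed the scatter but could also fall within it. For compound 3 the estimated value in this assay is 900 nM, with a range from 250 nM to 3200 nM.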

Compound 3, half-maximal inhibitory concentration: 410 nM
The estimate for compound 3 lay 2.2-fold (0.34 log units) above the measured number; measured number inside the range.
By their numbers in this assay, from the lowest: compounds 1 and 3 (each within the scatter of the next); then compound 2.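

Working notes on the phenyl change. In this assay, for the compounds shown here, replacing methyl with phenyl on an aromatic carbon, meta to a hydroxy group and para to a large group, gives a 6.2-fold lower number from compound 2 to compound 3 (0.80 log units; beyond the scatter) and is the first single-place change that can be read. The step lies beyond the scatter, so this position accepts one six-membered aromatic ring of carbon only where compound 2 has a single methyl carbon, and the number falls rather than rises with that larger group in place. Going by these compounds alone, the data show only that the number moves with this change, and no measurement here accounts for the size or direction of the step.

A single pair cannot show whether the gain comes from the aromatic ring itself or would also appear with a non-aromatic group at this position, such as a cyclohexyl ring or a longer alkyl chain, or with a phenyl carrying an amine or a carboxylic acid. As far as these compounds go, it also remains open whether phenyl has the same effect when the nitrile on the other ring is replaced by the two trifluoromethyl groups of compound 1.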